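Biphenyl amide series: cytotoxicity follow-up on compound 4

The compounds below may be only part of what the source reports. "The series", "measured", "known", "first", "only" and "open" are said of these compounds alone.

Working notes on a set of biphenyl amides sharing one core, read in an ADME assay on Raji cells (Homo sapiens) for cytotoxicity, read by CellTiter-Glo and resazurin assay, with a stated time of 72 h; on this read-out lower numbers stand for an effect already at smaller amounts and higher numbers for an effect only at larger amounts of compound. Compound 1 `CC(=O)c1cccc(-c2ccc(C(=O)N(Cc3cccc(OCCCCCC(=O)O)c3)C(C)C)cc2)c1` carries a 3-acetylphenyl group and a free carboxylic acid on the chain. In this assay compound 1 reaches only a limit, > 26000 nM. Compound 2 `COc1cc(F)cc(-c2ccc(C(=O)N(Cc3cccc(OCCCCCC(=O)O)c3)C(C)C)cc2)c1` has 3-fluoro-5-methoxyphenyl in place of 3-acetylphenyl on an aromatic carbon. In this assay compound 2 likewise reaches only a limit, > 26000 nM. Compound 3 `CCOC(=O)CCCCCOc1cccc(CN(C(=O)c2ccc(-c3cccc(C(C)=O)c3)cc2)C(C)C)c1` has ethyl in place of hydrogen on an oxygen next to a carbonyl group. In this assay compound 3 also reaches only a limit, > 26000 nM.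

Neither measured step can be sized: a step that the two limits leave unreadable from compound 1 to compound 2 and a step that the two limits leave unreadable from compound 1 to compound 3. All three values sit together, as stated by the limit of > 26000 nM in this assay, at which 3 of the 3 values shown sit. Compound 3 therefore stands nowhere distinguishable from the other two.

Compound 4 `CCOC(=O)CCCCCOc1cccc(CN(C(=O)c2ccc(-c3cccc(Cl)c3)cc2)C(C)C)c1` is not yet measured. Against compound 3 it shows (chloro in place of acetyl on an aromatic carbon). Among the compounds with values here, no measured step touches this change, and the two steps that exist are unreadable, so no direction can be drawn from them. Compound 4 is expected to remain at the limit, with an estimated step that the limit leaves unreadable from compound 3 to compound 4 from compound 3. The estimate for compound 4 is 30000 nM, within 13000 nM to 100000 nM.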

Compound 4, half-maximal effective concentration: > 18400 nM
Compound 4: a limit, no number (the forecaster's own chance of this, stated with the estimate: 85%); the middle value is on the limit's open side.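

Compound 4 reaches only a limit, > 18400 nM. Compound 3 also stands at a limit, so no step can be read between compound 3 and compound 4. The compounds shown leave open at what concentration any of the four would reach a half-maximal effect in this assay, and whether chloro in place of acetyl changes that concentration at all.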